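A Phenyl Group Added Twice on a Shared Core

The compounds below may be only part of what the source reports. "The series", "measured", "known", "first", "only" and "open" are said of these compounds alone.

Three compounds sharing one core were tested in a functional assay on PC-3 cells (Homo sapiens) for cytotoxicity, read by MTT assay, with a stated time of 72 h; on this read-out higher numbers stand for weaker inhibition and lower numbers for stronger inhibition. Compound 1 `COCNc1n[n+]([O-])c2ccccc2[n+]1[O-]` gives 7510 nM. Compound 2 `[O-][n+]1nc(NCOCc2ccccc2)[n+]([O-])c2ccccc21` gives 13400 nM, and compound 3 `CCOCNc1n[n+]([O-])c2ccccc2[n+]1[O-]` gives 15900 nM. Compound 2 differs from compound 1 by phenyl in place of hydrogen on a saturated chain carbon bound to an oxygen on a saturated carbon, and that change made a step of a 1.8-fold higher number from compound 1 to compound 2 (0.25 log units; within the scatter). Compound 3 differs from compound 1 by methyl in place of hydrogen on a saturated chain carbon bound to an oxygen on a saturated carbon, a step of a 2.1-fold higher number from compound 1 to compound 3 (0.33 log units; beyond the scatter). The numbers for compound 2 and compound 3 lie within the scatter of each other.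

Compound 4 `CC(OCNc1n[n+]([O-])c2ccccc2[n+]1[O-])c1ccccc1` has not been measured yet. It differs from compound 3 by phenyl in place of hydrogen on a saturated chain carbon bound to an oxygen on a saturated carbon and a saturated chain carbon. For the measured compounds named here, this is the same kind of change as the one from compound 1 to compound 2, though here the saturated chain carbon is bound not only to the oxygen but also to a saturated chain carbon. Resting on the step of a 1.8-fold higher number from compound 1 to compound 2 (0.25 log units; within the scatter), the expected step for compound 4 is a 1.5-fold higher number from compound 3 to compound 4 (0.18 log units; within the scatter). Compound 4 is therefore estimated at 24000 nM in this assay, expected to fall between 10000 nM and 55000 nM.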

Compound 4, half-maximal inhibitory concentration: 6080 nM
Compound 4: middle estimate off by 3.9-fold (0.60 log units), on the high side; measured number outside the range, below it.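

In this assay, phenyl in place of hydrogen gives a 2.6-fold lower number from compound 3 to compound 4 (0.42 log units; beyond the scatter), and this does not match what the same change does on the core of compound 1: the same change on two cores in this assay, a 1.8-fold higher number (0.25 log units; within the scatter) from compound 1 to compound 2 and a 2.6-fold lower number (0.42 log units; beyond the scatter) from compound 3 to compound 4, 4.7-fold (0.67 log units) apart, beyond the scatter of two such steps

Methyl in place of hydrogen, on the carbon that already carries the phenyl, gives a 2.2-fold lower number from compound 2 to compound 4 (0.34 log units; beyond the scatter), and this also differs from its counterpart: the same change on two cores in this assay, a 2.1-fold higher number (0.33 log units; beyond the scatter) from compound 1 to compound 3 and a 2.2-fold lower number (0.34 log units; beyond the scatter) from compound 2 to compound 4, 4.7-fold (0.67 log units) apart, beyond the scatter of two such steps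

Both comparisons rest on the same four compounds, so they are one finding seen from two sides: here the effects of the methyl and the phenyl do not simply add up, which shows that a step measured on one of these compounds cannot be carried to another, but it does not show why or whether this holds elsewhere in the series.

On these data alone, it remains open whether the lower number of compound 4 needs the phenyl itself, or whether a cyclohexyl ring or a longer chain in its place would give the same result. As far as these compounds go, it is also open whether an amine or a carboxylic acid on the phenyl would keep that number.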